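Swapping the phenyl substituent on a shared kinase-binding core

The source may report more compounds than this note shows. Statements on the series, on what has been measured and on what is new or still open speak of the compounds shown alone.

Compounds measured so far:
compound 1, `CCCS(=O)(=O)Nc1ccc(F)c(C(=O)c2n[nH]c3ncc(-c4ccccc4F)cc23)c1F`, 2%
compound 2, `CCCS(=O)(=O)Nc1ccc(F)c(C(=O)c2n[nH]c3ncc(-c4cccc(N)c4)cc23)c1F`, 1.6%
compound 3, `CCCS(=O)(=O)Nc1ccc(F)c(C(=O)c2n[nH]c3ncc(-c4cccc(N(C)C)c4)cc23)c1F`, 26%

In an assay for binding affinity to dual specificity mitogen-activated protein kinase kinase 4 (Homo sapiens), read by KINOMEscan, tested at 100 nM (on this read-out lower numbers stand for a stronger effect and higher numbers for a weaker effect at the one concentration tested), compound 3 stands apart: it gives the highest number of the three, and both of its distances are beyond the scatter, a number 24 percentage points higher from compound 1 to compound 3 (beyond the scatter) and a number 24.4 percentage points higher from compound 2 to compound 3 (beyond the scatter), so it is the weakest binder here. Compound 1 and compound 2 sit within the scatter of each other, a number 0.4 percentage points lower from compound 1 to compound 2 (within the scatter).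

Compound 4, `CCCS(=O)(=O)Nc1ccc(F)c(C(=O)c2n[nH]c3ncc(-c4ccc(S(=O)(=O)NC)cc4)cc23)c1F`, has not yet been measured. It differs from compound 3 in one place: 4-(methylsulfamoyl)phenyl in place of 3-(dimethylamino)phenyl on an aromatic carbon. Among the measured compounds shown here, no measured step carries this exact change. What the measured steps do show is that the group on this position can move the number by a modest amount in either direction, and that two different groups, in compound 1 and compound 2, both gave low numbers while only the dimethylamino group of compound 3 gave a high one. On that basis compound 4 is expected to fall back toward the low numbers, a step of about a number 18 percentage points lower from compound 3 to compound 4 (beyond the scatter), though with wide uncertainty. Compound 4 is estimated at 8%, within a range from 1% to 40%.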

Compound 4, a percentage reported as activity, at one concentration (the size of the read-out at that concentration, not a potency): 1.2%
Compound 4: middle estimate off by 6.8 percentage points, on the high side, and the stated range covers the measured number.
By their numbers in this assay, from the lowest: compounds 4, 2 and 1 (each within the scatter of the next); then compound 3.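

In this assay, 4-(methylsulfamoyl)phenyl brings the number back down, a number 24.8 percentage points lower from compound 3 to compound 4 (beyond the scatter), even though it is the larger group by heavy-atom count, so among these compounds a larger group on this aromatic carbon does not go with a higher number. The new number also cannot be told apart from the two earlier low numbers, a number 0.4 percentage points lower from compound 2 to compound 4 (within the scatter) and a number 0.8 percentage points lower from compound 1 to compound 4 (within the scatter), which leaves compound 3 as the only one of the four that stands out. Nothing available here explains why compound 3 differs.

From the compounds shown here alone, it remains open whether the higher number of compound 3 follows from the dimethylamino group itself or from where it sits on the phenyl ring. A 3-(methylamino)phenyl group would test the first possibility and a 4-(dimethylamino)phenyl group the second.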